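The compounds below may be only part of what the source reports. "The series", "measured", "known", "first", "only" and "open" are said of these compounds alone.

Three members of the series have numbers in a functional assay for agonist activity at G protein-coupled receptor 88 (Homo sapiens), read by HTRF and cAMP accumulation; on this read-out higher numbers stand for an effect only at larger amounts of compound and lower numbers for an effect already at smaller amounts. Compound 1 `CC[C@H](C)[C@H](N)CN(C(=O)[C@@H]1C[C@H]1c1ccccc1)c1ccc(-c2ccc(OC(C)C)cc2)cc1` gives 72 nM, compound 2 `CCOc1ccc(-c2ccc(N(C[C@@H](N)[C@@H](C)CC)C(=O)[C@@H]3C[C@H]3c3ccccc3)cc2)cc1` gives 90 nM, and compound 3 `CC[C@H](C)[C@H](N)CN(C(=O)[C@@H]1C[C@H]1c1ccccc1)c1ccc(-c2ccc(N)cc2)cc1` gives 320 nM. Between the two alkoxy analogues the step of a 1.3-fold higher number from compound 1 to compound 2 (0.10 log units; within the scatter) is small, whereas compound 3 carries the highest number of the three and is set apart from both by the steps of a 4.4-fold higher number from compound 1 to compound 3 (0.65 log units; beyond the scatter) and a 3.6-fold higher number from compound 2 to compound 3 (0.55 log units; beyond the scatter).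

Compound 4 `CC[C@H](C)[C@H](N)CN(C(=O)[C@@H]1C[C@H]1c1ccccc1)c1ccc(-c2ccc(CN)cc2)cc1` is the next step from compound 3: aminomethyl in place of amino on an aromatic carbon; cut one bond further out, the same difference reads 4-aminophenyl to 4-(aminomethyl)phenyl. Going by the values given here, no measured step concerns this change. The two steps that reach compound 3 only show that an amino group in this place reads higher than isopropoxy or ethoxy; nothing in the series bears on whether extending it by one saturated carbon moves the number in either direction. The expected step is therefore a 1.1-fold higher number from compound 3 to compound 4 (0.04 log units; within the scatter), one that need not exceed the scatter, with a wide range for lack of precedent. The estimate for compound 4 is 350 nM, between 120 nM and 1000 nM.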

Compound 4, half-maximal effective concentration: > 30000 nM
Compound 4 ended at the assay's limit; the forecaster's own chance of this, stated with the estimate: 5%; middle value at least 85-fold (1.93 log units) away from the limit.
By their numbers in this assay, from the lowest: compounds 1 and 2 (each within the scatter of the next); then compound 3. At a limit, above all of these: compound 4.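

In this assay compound 4 stands at a limit, > 30000 nM, and not at a measured number. The earlier compounds shown here showed only modest steps at this position, para to a large group, whereas aminomethyl in place of amino gives an at least 93-fold higher number from compound 3 to compound 4 (1.97 log units; beyond the scatter), and the comparisons with the alkoxy analogues give an at least 330-fold higher number from compound 2 to compound 4 (2.52 log units; beyond the scatter) and an at least 410-fold higher number from compound 1 to compound 4 (2.61 log units; beyond the scatter); one saturated carbon added to the amino group is thus enough to take the reading from the measured range to the limit. Each of these steps gives only a lower bound on the true size: the limit of > 30000 nM in this assay, at which 1 of the 4 values shown sits.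

From the compounds shown here alone, whether the sharp rise needs the amine on that saturated carbon, or follows from the saturated carbon alone, stays open. A hydroxymethyl or methoxymethyl group here would separate these two, and a dimethylamino group would show how far the nitrogen itself can be substituted.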